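A Methoxy Swap on the Triazole's Aryl Group

The compounds below may be only part of what the source reports. "The series", "measured", "known", "first", "only" and "open" are said of these compounds alone.

- Compound 1 `CC1(C)[C@H]2CC[C@]1(C)N(Cc1cn(-c3ccc(C#N)cc3)nn1)C(=O)C2` gives 50 nM
- Compound 2 `CC1(C)[C@H]2CC[C@]1(C)N(Cc1cn(-c3ccc(F)cc3)nn1)C(=O)C2` gives 90 nM

Both numbers come from a functional assay on HepG2 cells (Homo sapiens) for inhibition, read by MTT assay, with a stated time of 24 h; on this read-out lower numbers stand for stronger inhibition and higher numbers for weaker inhibition. Going by the values given here, only one other measurement sits alongside compound 2 (90 nM) so far. The gap between the two is a 1.8-fold higher number from compound 1 to compound 2 (0.26 log units; within the scatter), so the pair cannot be ranked.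

Compound 3 `COc1ccccc1-n1cc(CN2C(=O)C[C@@H]3CC[C@@]2(C)C3(C)C)nn1` keeps the shared core but carries 2-methoxyphenyl in place of 4-fluorophenyl on an aromatic nitrogen. The one measured step that bears on this is the swap of fluoro for cyano described above, which also changes a group on the aromatic ring attached to that nitrogen. Among the compounds with values here, it was small, but no measured compound carries a 2-methoxyphenyl group, so it offers only weak guidance. The expectation therefore rests on compound 2 (90 nM) and on that small step, and no clear step beyond the scatter is expected in this assay. The estimated change is a 1.3-fold higher number from compound 2 to compound 3 (0.12 log units; within the scatter). For compound 3 the expected value is 120 nM, with an estimated range from 40 nM to 400 nM.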

Compound 3, half-maximal inhibitory concentration: 110 nM
For compound 3 the middle estimate is 1.1-fold (0.04 log units) above the measured one; measured number inside the range.
By their numbers in this assay, from the lowest: compounds 1, 2 and 3 (each within the scatter of the next, the first and the last beyond it).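

Going by these compounds alone, compound 3 brings the first 2-methoxyphenyl group to this aromatic nitrogen, and in this assay the swap from 4-fluorophenyl gives a 1.2-fold higher number from compound 2 to compound 3 (0.09 log units; within the scatter) and so cannot be told apart from no change at all. Measured against the 4-cyanophenyl group of compound 1, the same group gives a 2.2-fold higher number from compound 1 to compound 3 (0.34 log units; beyond the scatter) and thereby provides the first modest separation in this small set, while compound 2 stays within the scatter of both other compounds. The position therefore tolerates a 2-methoxyphenyl group, which carries one hydrogen-bond acceptor where 4-fluorophenyl carries none, with at most a modest shift in the read-out, and nothing at hand explains either step.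

From the compounds shown here alone, all three compounds carry a phenyl ring with one substituent on this nitrogen, so it remains open how a plain phenyl ring, a benzyl group or a pyridine ring would fare here. Going by these compounds, it also remains open whether an amine or a carboxylic acid on the phenyl ring would keep the numbers in this range or move them well beyond the scatter.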